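Propyl in place of tert-butyl: an expected small step

The compounds below may be only part of what the source reports. "The series", "measured", "known", "first", "only" and "open" are said of these compounds alone.

compound 1, `CCO/C(O)=C\c1nncc2cncn12`: > 48000 nM
compound 2, `CCc1nnc(O)n2c(C(C)(C)C)nc(C)c12`: 26000 nM

Of the compounds shown here, two have been measured in a functional assay for inhibition, with Homo sapiens as the target; a higher number here means a weaker inhibitor, a lower number a stronger inhibitor. For compound 1 the value > 48000 nM is a limit of the assay rather than a number; this is the limit of > 48000 nM in this assay, at which 1 of the 2 values shown sits. Compound 2 gives 26000 nM. This is the only number shown. Compound 3, `CCCc1nc(C)c2c(CC)nnc(O)n12`, has not yet been measured. It differs from compound 2 in one place: propyl in place of tert-butyl on an aromatic carbon. Within the data shown here, no measured step of this kind is available, so the change can be judged only from the structures. The expected step of a 1.2-fold higher number from compound 2 to compound 3 (0.06 log units; within the scatter) in this assay is small, with no direction beyond the usual scatter. Compound 3 is therefore estimated to give about 30000 nM, within a range from 10000 nM to 90000 nM.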

Compound 3, half-maximal inhibitory concentration: 15600 nM
Compound 3: middle estimate off by 1.9-fold (0.28 log units), on the high side; measured number inside the range.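

Propyl in place of tert-butyl on an aromatic carbon now has a measured step in this assay: a 1.7-fold lower number from compound 2 to compound 3 (0.22 log units; within the scatter). At this carbon, between two ring nitrogen atoms, the branched tert-butyl and the propyl chain are therefore not told apart by this read-out, and the position accepts either group without a change beyond the scatter. Nothing shown here accounts for the size of this step, which rests on a single pair of compounds.

Still open, on these data alone, is whether a group of another kind on this carbon, such as an amine, a carboxylic acid or a longer chain, would move the number beyond the scatter. Also open, as far as these compounds go, is what the methyl group contributes on the ring atom two ring bonds from this carbon.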